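Replacing 3-Methylphenyl with 4-Chlorophenyl on an Amide Nitrogen

The source may hold more compounds than are shown below. What is called first, only, known or untested is meant among the compounds shown, and "the series" means these compounds.

Measured so far in a functional assay on T47D cells (Homo sapiens) for inhibition, read by CCK-8 assay, with a stated time of 72 h, tested at 1 uM; a lower number here means less inhibition of growth, a higher number more inhibition of growth at the concentration tested:
compound 1, `CN(C)C(=O)c1cc2cnc(Nc3ccc(NC(=O)C4(C(=O)Nc5cccc(C(F)(F)F)c5)CC4)cc3)nc2n1C1CCCC1`, gives 9.7%
compound 2, `CN(C)C(=O)c1cc2cnc(Nc3ccc(NC(=O)C4(C(=O)Nc5cccc(Cl)c5)CC4)cc3)nc2n1C1CCCC1`, gives 39.3%
compound 3, `Cc1cccc(NC(=O)C2(C(=O)Nc3ccc(Nc4ncc5cc(C(=O)N(C)C)n(C6CCCC6)c5n4)cc3)CC2)c1`, gives 45.7%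

All three share one core and differ only in the group on one aromatic ring of the outer amide. Compound 3 has the highest of the three numbers, but its lead over compound 2 is small: a number 6.4 percentage points higher from compound 2 to compound 3 (within the scatter). Its lead over compound 1 is real: a number 36 percentage points higher from compound 1 to compound 3 (beyond the scatter), and compound 2 likewise stands clearly above compound 1, a number 29.6 percentage points higher from compound 1 to compound 2 (beyond the scatter).

Compound 4, `CN(C)C(=O)c1cc2cnc(Nc3ccc(NC(=O)C4(C(=O)Nc5ccc(Cl)cc5)CC4)cc3)nc2n1C1CCCC1`, has not yet been measured. The change from compound 3 is 4-chlorophenyl in place of 3-methylphenyl on an amide-type nitrogen. Two things move at once: methyl gives way to chlorine, and the group shifts from one ring position to another. Only the first part has a measured counterpart, the step from compound 2 to compound 3, which stayed within the scatter. Nothing measured here speaks to the shift in position. The expectation for compound 4 is therefore a number near that of compound 3, with a step of about a number 7.7 percentage points lower from compound 3 to compound 4 (within the scatter), and a wide range to allow for the unknown effect of the new position. Compound 4 is estimated at 38%, between 12% and 60%.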

Compound 4, percent growth inhibition at one concentration: 22.8%
For compound 4 the middle estimate is 15.2 percentage points above the measured one; the range from low to high includes it.
By their numbers in this assay, from the lowest: compound 1; then compound 4; then compounds 2 and 3 (each within the scatter of the next).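

Moving the chlorine alone, with 4-chlorophenyl in place of 3-chlorophenyl on the amide-type nitrogen, gives a number 16.5 percentage points lower from compound 2 to compound 4 (beyond the scatter) in this assay and shows that the ring position of the substituent matters here, something compounds 1, 2 and 3 could not show, as all three carry their group in the same place. The change from 3-methylphenyl to 4-chlorophenyl, a number 22.9 percentage points lower from compound 3 to compound 4 (beyond the scatter), fits this reading, as the exchange of methyl and chloro with the position held fixed stayed within the scatter. The new position does not bring the lowest number of the set, since a number 13.1 percentage points higher from compound 1 to compound 4 (beyond the scatter), and nothing in hand explains the effect of the position or of any of these groups.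

From the compounds shown here alone, it remains open whether 4-methylphenyl or 4-(trifluoromethyl)phenyl would also read lower than its 3-substituted partner, so this position effect is established only for chlorine. Going by these compounds, how the same ring would behave with an amine or a carboxylic acid in place of these groups also remains open, as does the effect of a second chlorine on it.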